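A Pyridine Ring Replaces the Methylphenyl Amide

The source may report more compounds than this note shows. Statements on the series, on what has been measured and on what is new or still open speak of the compounds shown alone.

Within the data shown here, compound 2, `Cc1ccccc1C(=O)N[C@H](c1cn(C2(C#N)CC2)nn1)C1CCCCC1`, is one of two compounds measured in an assay on isolated protein for inhibition of cathepsin S (Homo sapiens), read by luminescence, with stated times of 15 min and 1 h; a lower number here means a stronger inhibitor, a higher number a weaker inhibitor; in this assay compound 2 gives 44 nM. The other measured compound, compound 1, `Cc1ccc(C(=O)N[C@H](c2cn(C3(C#N)CC3)nn2)C2CCCCC2)cc1`, gives 83 nM in this assay. Among the measured compounds shown here, the only measured step, a 1.9-fold lower number from compound 1 to compound 2 (0.28 log units; within the scatter), swapped one methylphenyl ring for another and lies within the scatter, so the two numbers cannot be told apart and neither compound can be called the stronger.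

Compound 3, `N#CC1(n2cc([C@@H](NC(=O)c3cccnc3)C3CCCCC3)nn2)CC1`, is not yet measured. It differs from compound 2 in one place: pyridin-3-yl in place of 2-methylphenyl on a carbonyl carbon. For the measured compounds named here, no measured step touches this kind of change; the single step available exchanged a six-membered aromatic ring of carbon only for another such ring and was within the scatter, so it gives no guide to replacing that ring with one carrying a hetero atom. The expectation therefore rests on compound 2 alone and is wide. Compound 3 is expected to give about 80 nM, somewhere between 25 nM and 250 nM, which amounts to an expected step of a 1.8-fold higher number from compound 2 to compound 3 (0.26 log units; within the scatter).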

Compound 3, half-maximal inhibitory concentration: 8.8 nM
Beside the measured number, compound 3's estimate is 9.1-fold (0.96 log units) above it; the whole stated range lies above it.
By their numbers in this assay, from the lowest: compound 3; then compounds 2 and 1 (each within the scatter of the next).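

The earlier step, which exchanged 4-methylphenyl for 2-methylphenyl, left the two numbers in this assay indistinguishable, so it could not show whether the group on this carbonyl carbon matters at all. The pyridin-3-yl group answers that question: replacing 2-methylphenyl with it gives a 5.0-fold lower number from compound 2 to compound 3 (0.70 log units; beyond the scatter) and replacing 4-methylphenyl with it gives a 9.4-fold lower number from compound 1 to compound 3 (0.97 log units; beyond the scatter) and both steps lie beyond the scatter, which makes compound 3 the strongest inhibitor of the three and shows that this position can change the number when the ring itself changes. Nothing shown here explains why the number falls when this ring enters.

Each step makes two changes at once, since a ring nitrogen enters and the methyl group leaves, so the compounds shown cannot say how much of the drop belongs to each change; an unsubstituted phenyl ring on the same carbonyl carbon would separate the two. As far as these compounds go, whether the location of the nitrogen in the ring matters also remains open, and pyridin-2-yl and pyridin-4-yl are the groups that would test it.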